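A few compounds are considered here, and "the series" means these few. Any claim that something is new, unique, unknown or untested is made for them only; others in the source may bear on it.

Among the compounds with values here, compound 3 `CC1(C)C[C@H](Nc2cc(NCc3cnccc3C(F)(F)F)ncc2C#N)CC[C@@H]1O` is the only compound here with a number in an assay on isolated protein for inhibition of protein kinase C delta type (Homo sapiens), read by TR-FRET, with a stated time of 2 h; a lower number here means a stronger inhibitor, a higher number a weaker inhibitor: compound 3 gives 500 nM. Compound 1 `N#Cc1cnc(NCc2cnccc2C(F)(F)F)cc1NC[C@H]1C[C@H](O)C1` gives only a limit in this assay, > 10000 nM. Compound 2 `CO[C@H]1CC[C@H](Nc2cc(NCc3cnccc3C(F)(F)F)ncc2C#N)CC1` likewise gives only a limit, > 10000 nM. The step from compound 1 to compound 3 was an at least 20-fold lower number from compound 1 to compound 3 (1.30 log units; beyond the scatter), and from compound 2 to compound 3 it was an at least 20-fold lower number from compound 2 to compound 3 (1.30 log units; beyond the scatter); the step from compound 1 to compound 2 is a step that the two limits leave unreadable from compound 1 to compound 2 because both sit at the limit of > 10000 nM in this assay, at which 2 of the 3 values shown sit. Compound 4 `CC1(C)C[C@@H](Nc2cc(NCc3cnccc3C(F)(F)F)ncc2C#N)CC[C@@H]1O` differs from compound 3 in that (the two compounds have the same atoms and bonds and differ only in configuration as drawn: 1 of 2 stereo elements differ; a stereocentre at a saturated ring carbon is drawn R in compound 3 and S in compound 4). Within the data shown here, none of the measured steps changes only a stereocentre, so they give no direct guide to the size of this step. Compound 4 is therefore expected at about 1500 nM, within a range of 300 nM to 8000 nM. The step this estimate implies is expected to be a 3.0-fold higher number from compound 3 to compound 4 (0.48 log units; beyond the scatter).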

Compound 4, half-maximal inhibitory concentration: 2400 nM
For compound 4 the middle estimate is 1.6-fold (0.20 log units) below the measured one; the measured number falls inside the stated range.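

In this assay, configuration at this saturated ring carbon matters on its own, with a 4.8-fold higher number from compound 3 to compound 4 (0.68 log units; beyond the scatter) while atoms and bonds stay the same: the fact that compounds 3 and 4 differ only in the configuration as drawn The 4-hydroxy-3,3-dimethylcyclohexyl group gives a readable number in both configurations, with an at least 4.1-fold lower number from compound 2 to compound 4 (0.61 log units; beyond the scatter) and an at least 4.1-fold lower number from compound 1 to compound 4 (0.61 log units; beyond the scatter). Those two steps start from a limit and not from a number: the limit of > 10000 nM in this assay, at which 2 of the 4 values shown sit.

As far as these compounds go, it remains open whether the hydroxyl or the two methyl groups account for the gain over the 4-methoxycyclohexyl group. From the compounds shown here alone, it also remains open how an amine or a carboxylic acid in place of that hydroxyl would read.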